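Methoxy to Benzyloxy on the Aryl Ring of a Urea Series

A few compounds are considered here, and "the series" means these few. Any claim that something is new, unique, unknown or untested is made for them only; others in the source may bear on it.

In an assay on microsomes for inhibition of acyl-CoA:cholesterol acyltransferase (Oryctolagus cuniculus) (a higher number here means a weaker inhibitor, a lower number a stronger inhibitor), the three measured compounds give:
Compound 1, `Cc1ccc(C2(CNC(=O)Nc3c(C(C)C)cccc3C(C)C)CCCC2)cc1`: 25 nM
Compound 2, `CC(C)c1cccc(C(C)C)c1NC(=O)NCC1(c2ccc(F)cc2)CCCC1`: 23 nM
Compound 3, `COc1ccc(C2(CNC(=O)Nc3c(C(C)C)cccc3C(C)C)CCCC2)cc1`: 31 nM

Compound 3 shows the highest of the three numbers, but its steps from the other two, a 1.2-fold higher number from compound 1 to compound 3 (0.09 log units; within the scatter) and a 1.3-fold higher number from compound 2 to compound 3 (0.13 log units; within the scatter), both lie within the scatter, as does a 1.1-fold lower number from compound 1 to compound 2 (0.04 log units; within the scatter). The three compounds therefore cannot be ordered against each other in this assay.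

Compound 4, `CC(C)c1cccc(C(C)C)c1NC(=O)NCC1(c2ccc(OCc3ccccc3)cc2)CCCC1`, differs from compound 3 by phenyl in place of hydrogen on a saturated chain carbon bound to an oxygen on an aromatic ring. For the measured compounds named here, none of the measured steps makes this change: each of them only exchanges one small group on the aromatic carbon, and each stays within the scatter. Going by the values given here, there is thus no measured step that bears directly on the move from compound 3 to compound 4, only the observation that the three small groups are tolerated alike. The expected step is a 1.3-fold higher number from compound 3 to compound 4 (0.11 log units; within the scatter), a modest weakening that is not firmly supported in either direction. Compound 4 is therefore estimated at 40 nM, with a range from 12 nM to 130 nM.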

Compound 4, half-maximal inhibitory concentration: 34 nM
The estimate for compound 4 lay 1.2-fold (0.07 log units) above the measured number; the measured number falls inside the stated range.
By their numbers in this assay, from the lowest: compounds 2, 1, 3 and 4 (each within the scatter of the next).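

Placing phenyl on the saturated chain carbon bound to an oxygen on an aromatic ring turns methoxy into benzyloxy, and in this assay this larger change gives a 1.1-fold higher number from compound 3 to compound 4 (0.04 log units; within the scatter). Set against the other two compounds, benzyloxy gives a 1.5-fold higher number from compound 2 to compound 4 (0.17 log units; within the scatter) and a 1.4-fold higher number from compound 1 to compound 4 (0.13 log units; within the scatter), so at this position a group carrying a whole six-membered aromatic ring cannot be told apart from methyl, fluoro or methoxy in this assay. Nothing in the data shown accounts for this tolerance.

On these data alone, it remains open whether the tolerance holds for a longer chain between the oxygen and the phenyl, such as phenethyloxy, or for a phenyl carrying an amine or a carboxylic acid. For the compounds shown here, it is also open whether benzyloxy would read the same way on a core other than the one these four compounds share.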